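Swapping a pyrazole for an isoxazole on an inactive compound

A few compounds are considered here, and "the series" means these few. Any claim that something is new, unique, unknown or untested is made for them only; others in the source may bear on it.

These compounds share one core, and the measured ones have been tested in a functional assay on BJAB cells (Homo sapiens) for antiproliferative activity, with a stated time of 4 days; on this read-out higher numbers stand for an effect only at larger amounts of compound and lower numbers for an effect already at smaller amounts. Compound 1, `Cc1c(-c2cc(Cl)cc(Cl)c2)c(C(=O)O)nn1-c1nc(-c2cccnc2)c(SC(C)C)s1`, shows "not active" (no number reported), with no number reported. Compound 2, `Cc1c(-c2cc(Cl)cc(Cl)c2)c(C(=O)O)nn1-c1nc(-c2cnn(C)c2)c(SC(C)C)s1`, likewise shows "not active" (no number reported) in this assay, again without a number. Only compound 3, `COc1ccc(-c2c(C)nn(-c3nc(-c4ccc(Cl)c(Cl)c4)c(SC(C)C)s3)c2C(=O)O)cc1`, which differs from the others in more than one place, returns a value, giving 2100 nM in this assay. Compound 2 therefore stands among the compounds for which no concentration can be stated at all; it is one of two such entries, and nothing on the numbers shown sets it apart from compound 1.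

Compound 4, `Cc1oncc1-c1nc(-n2nc(C(=O)O)c(-c3cc(Cl)cc(Cl)c3)c2C)sc1SC(C)C`, has not yet been measured. It differs from compound 2 in a single group: 5-methyl-1,2-oxazol-4-yl in place of 1-methyl-1H-pyrazol-4-yl on an aromatic carbon. Because compound 2 gives "not active" (no number reported), there is no starting number from which a step could be sized, and the change is a small one. No step beyond the usual scatter is expected in this assay, so compound 4 is expected to remain weak or to return no number at all. Compound 4 is estimated at 8000 nM, within a range from 2000 nM to 30000 nM.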

Compound 4, half-maximal effective concentration: > 44000 nM
Compound 4 gave a limit, no number; the forecaster's own chance of this, stated with the estimate: 60%; middle value at least 5.5-fold (0.74 log units) from the limit.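

In this assay compound 4 gives only a limit, > 44000 nM, and not a number. Among these compounds, compound 2 has no number either, and no step between compound 2 and compound 4 can be read. The compounds shown leave open whether replacing 1-methyl-1H-pyrazol-4-yl with 5-methyl-1,2-oxazol-4-yl changes the result in this assay at all.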